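Chloro to trifluoromethyl: estimating compound 4

The source may hold more compounds than are shown below. What is called first, only, known or untested is meant among the compounds shown, and "the series" means these compounds.

Three compounds have been measured in a functional assay on NCI/ADR-RES cells (Homo sapiens) for inhibition, read by sulforhodamine B assay, with a stated time of 48 h; a higher number here means a weaker inhibitor of growth, a lower number a stronger inhibitor of growth:
- compound 1 `COc1cc(-c2nn(-c3cccc(NC(=O)Nc4ccc(Cl)c(Cl)c4)c3)cc2-c2ccncc2)ccc1Cl` gives 990 nM
- compound 2 `O=C(Nc1cccc(-n2cc(-c3ccncc3)c(-c3ccc(Cl)c(O)c3)n2)c1)Nc1ccc(Cl)c(Cl)c1` gives 2740 nM
- compound 3 `O=C(Nc1cccc(-n2cc(-c3ccncc3)c(-c3ccc(Cl)c(O)c3)n2)c1)Nc1cc(C(F)(F)F)cc(C(F)(F)F)c1` gives 1070 nM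

Compound 1 has the lowest of the three numbers. Compound 3 sits within the usual scatter of it, so the two cannot be told apart, while compound 2 lies beyond the scatter on the higher side. Compound 4 `COc1cc(-c2nn(-c3cccc(NC(=O)Nc4ccc(Cl)c(C(F)(F)F)c4)c3)cc2-c2ccncc2)ccc1Cl` is compound 1 with one change: trifluoromethyl in place of chloro on an aromatic carbon.

Among the compounds with values here, the only step counted so far, a 2.8-fold higher number from compound 1 to compound 2 (0.44 log units; beyond the scatter), concerns a different place in the molecule and says nothing about this change. Within the data shown here, compound 2 and compound 3 share everything except the ring that carries the chloro or trifluoromethyl groups, and their two values stand side by side above; no counted step joins them. Nothing measured here therefore speaks directly to swapping a single chloro for a trifluoromethyl.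

For compound 4 a step of a 1.1-fold lower number from compound 1 to compound 4 (0.04 log units; within the scatter) is expected, within the scatter, and its value is estimated at 900 nM, in the range 400 nM to 2000 nM.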

Compound 4, concentration for 50% growth inhibition: 1040 nM
For compound 4 the middle estimate is 1.2-fold (0.06 log units) below the measured one; the measured number falls inside the stated range.
By their numbers in this assay, from the lowest: compounds 1, 4 and 3 (each within the scatter of the next); then compound 2.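

In this assay, changing the 3,4-dichlorophenyl of compound 1 to the 4-chloro-3-(trifluoromethyl)phenyl of compound 4 gives a 1.1-fold higher number from compound 1 to compound 4 (0.02 log units; within the scatter). Within the data shown here, this is the first direct reading of this swap, and it shows that at this position, ortho to a chloro group, trifluoromethyl with its four heavy atoms can replace a chloro of one heavy atom with no change that can be told from scatter. No measurement of any property of these two groups is available to account for this result.

One swap on one compound cannot show how much this position tolerates in general, so a methyl group, a nitrile or an amine here might give a different outcome. On these data alone, it also remains open whether the same swap would read alike in compound 2, which carries a hydroxyl in place of the methoxy group of compound 1.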